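The compounds below may be only part of what the source reports. "The series", "measured", "known", "first", "only" and "open" are said of these compounds alone.

Compounds measured in a functional assay on KBVIN cells (Homo sapiens) for antiproliferative activity, read by sulforhodamine B assay, with a stated time of 3 days; on this read-out higher numbers stand for an effect only at larger amounts of compound and lower numbers for an effect already at smaller amounts:
- compound 1, `CCC1=C(O)c2c(oc(-c3ccc(C)cc3)cc2=O)C(CC)(CC)C1=O`: 0.08 uM
- compound 2, `CCC1=C(O)c2c(oc(-c3ccc(Br)cc3)cc2=O)C(CC)(CC)C1=O`: 15.7 uM
- compound 3, `CCC1=C(O)c2c(oc(-c3cccc(OC)c3)cc2=O)C(CC)(CC)C1=O`: 1.22 uM

Compound 3 stands in the middle of the three: it is separated from compound 1 by a 15-fold higher number from compound 1 to compound 3 (1.18 log units; beyond the scatter) and from compound 2 by a 13-fold lower number from compound 2 to compound 3 (1.11 log units; beyond the scatter), both steps beyond the scatter, so compound 3 is neither the strongest nor the weakest of the set.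

Compound 4, `CCC1=C(O)c2c(oc(-c3ccc(OC)c(F)c3)cc2=O)C(CC)(CC)C1=O`, is not yet measured. It differs from compound 3 by 3-fluoro-4-methoxyphenyl in place of 3-methoxyphenyl on an aromatic carbon.

Among the compounds with values here, no measured step matches this change directly. Within the data shown here, the steps that bear on it are those that alter the substitution of the same aryl group: a 200-fold higher number from compound 1 to compound 2 (2.29 log units; beyond the scatter) shows how much the number can move when the group on that ring changes, and a 15-fold higher number from compound 1 to compound 3 (1.18 log units; beyond the scatter) and a 13-fold lower number from compound 2 to compound 3 (1.11 log units; beyond the scatter) show that compound 3 sits between the two 4-substituted cases. The 4-methylphenyl of compound 1 gave the lowest number, the 4-bromophenyl of compound 2 the highest; a 4-methoxy group with a fluoro beside it lies outside this span, and its effect cannot be inferred with confidence.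

A modest step toward a lower number is expected, a 2.4-fold lower number from compound 3 to compound 4 (0.39 log units; beyond the scatter), with wide uncertainty. Compound 4 is estimated at 0.5 uM, between 0.08 uM and 3 uM.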

Compound 4, concentration for half-maximal effect: 0.1 uM
Estimate against measurement, compound 4: 5.0-fold (0.70 log units) above; measured number inside the range.
By their numbers in this assay, from the lowest: compounds 1 and 4 (each within the scatter of the next); then compound 3; then compound 2.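

In this assay, 3-fluoro-4-methoxyphenyl in place of 3-methoxyphenyl on the same aromatic carbon of the shared core gives a 12-fold lower number from compound 3 to compound 4 (1.09 log units; beyond the scatter), so a change confined to this aryl group can move the number a long way even when the leaving and entering groups both carry a methoxy. The new group also gives a 1.3-fold higher number from compound 1 to compound 4 (0.10 log units; within the scatter), which shows that the low end of the series is not tied to the 4-methylphenyl group alone. At the same time, a 160-fold lower number from compound 2 to compound 4 (2.20 log units; beyond the scatter) leaves the 4-bromophenyl group of compound 2 on its own at the high end, and that group goes against any reading that a substituent in the 4 place of the aryl ring is enough for a low number.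

Nothing shown here gives a reason for the size of these steps. Still open, as far as these compounds go, is which part of the 3-fluoro-4-methoxyphenyl group carries the step, which 4-methoxyphenyl and 3-fluorophenyl would separate, and how an aminophenyl or a carboxyphenyl group would read at this position in this assay.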